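Fluoro for Chloro in a Series Without Cytotoxicity

This account rests on a few compounds, and the source may have more. Where it says the series, first, only, none or still open, it means among the compounds named here.

Measured compounds:
compound 1, `Cc1cc(NC(=O)Nc2ccc(C)c(Cl)c2)c2ccccc2n1`: > 25000 nM
compound 2, `Cc1cc(NC(=O)Nc2cccc(Cl)c2)c2ccccc2n1`: > 25000 nM
compound 3, `Cc1cc(NC(=O)Nc2cc(Cl)cc(Cl)c2)c2ccccc2n1`: > 25000 nM

In an ADME assay on BJ cells (Homo sapiens) for cytotoxicity, with a stated time of 72 h (a lower number here means that less compound is needed, a higher number that more compound is needed for the effect), compound 1 gives > 25000 nM, which is a limit of the assay and not a number. Compound 2 likewise gives > 25000 nM, again a limit. Compound 3 gives > 25000 nM, a limit as well. Compound 2 therefore stands at the same limit as both of its neighbours, and nothing here separates it from them.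

The compound still to be measured is compound 4, `Cc1cc(NC(=O)Nc2cccc(F)c2)c2ccccc2n1`. It differs from compound 2 in one place: fluoro in place of chloro on an aromatic carbon

Two measured steps border on this change. The step that the two limits leave unreadable from compound 1 to compound 2 and the step that the two limits leave unreadable from compound 2 to compound 3 both run between limits, so their sizes cannot be read. Within the data shown here, the only thing the three values share is the limit of > 25000 nM in this assay, at which 3 of the 3 values shown sit, and none of the steps reveals a size in either direction.

Given that compound 2 sits at the limit and that both known steps stay within it, compound 4 is expected to show a step of a number no higher from compound 2 to compound 4 (the limit leaves the size open), that is, none that can be read. Compound 4 is estimated at 25000 nM, with a range from 12000 nM to 60000 nM, most likely reported only as a limit.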

Compound 4, half-maximal effective concentration: > 25000 nM
Compound 4: only a limit was reported; the forecaster's own chance of this, stated with the estimate: 85%; the middle value lies on the limit itself.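

Compound 4 gives > 25000 nM in this assay as a limit of the assay and not a number. Among these compounds, compound 2 also stands at a limit, so no step from it to compound 4 can be read. The four compounds share one ceiling: the limit of > 25000 nM in this assay, at which 4 of the 4 values shown sit.

The compounds shown leave open at what concentration, if any, each would reach the effect, and whether fluoro and chloro differ at all.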